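A few compounds are considered here, and "the series" means these few. Any claim that something is new, unique, unknown or untested is made for them only; others in the source may bear on it.

For the measured compounds named here, compound 1, with the structure `CC(C)(C)c1cc(C2SCC(=O)N2CCCN)cc(C(C)(C)C)c1O`, is the weaker of the two compounds measured so far. In a functional assay on aorta for inhibition of Voltage-dependent L-type calcium channel subunit alpha-1C (Rattus norvegicus) (a higher number here means a weaker inhibitor, a lower number a stronger inhibitor), compound 1 gives 4400 nM. Compound 2, with the structure `CC(C)(C)c1cc(C2SCC(=O)N2CCCN2CCC(Cc3ccccc3)CC2)cc(C(C)(C)C)c1O`, gives in this assay 210 nM, a lower number than that of compound 1, and the gap between the two lies beyond the scatter of repeated measurements.

Compound 3, with the structure `CN(CCCN1C(=O)CSC1c1cc(C(C)(C)C)c(O)c(C(C)(C)C)c1)Cc1ccccc1`, has not yet been measured in this assay. It differs from compound 1 in one place: benzyl(methyl)amino in place of amino on a saturated chain carbon, three bonds along the chain from an amide-type nitrogen in a ring. Going by the values given here, since no measured pair shows exactly this change, its effect can only be judged from the two values at hand. A larger substituent on that chain nitrogen, as in compound 2, goes along with a lower number, so a step of similar direction is expected here, estimated as a 13-fold lower number from compound 1 to compound 3 (1.10 log units; beyond the scatter). Compound 3 is therefore expected to reach about 350 nM in this assay, within a range from 120 nM to 1000 nM.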

Compound 3, half-maximal inhibitory concentration: 600 nM
Compound 3: middle estimate off by 1.7-fold (0.23 log units), on the low side, and the stated range covers the measured number.
By their numbers in this assay, from the lowest: compound 2; then compound 3; then compound 1.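

Replacing amino with benzyl(methyl)amino on this chain gives a 7.3-fold lower number from compound 1 to compound 3 (0.87 log units; beyond the scatter) in this assay. For the compounds shown here, this is the first measured step in which only the group at the end of the chain changes, so it shows that this place alone can move the number by more than the scatter. The change swaps a group carrying a hydrogen-bond donor for a larger one with none and adds a six-membered aromatic ring, but no measurement here says which of these differences matters.

The compounds shown do not separate the benzyl part from the methyl part, so a benzylamino or a methylamino group at this place would be informative. As far as these compounds go, it also remains open how a longer chain carrying the same benzyl(methyl)amino group would compare with compound 3.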